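Replacing tert-butyl with piperidin-1-yl in compound 2

The source may report more compounds than this note shows. Statements on the series, on what has been measured and on what is new or still open speak of the compounds shown alone.

In a functional assay on U-251 cells (Homo sapiens) for inhibition, read by sulforhodamine B assay, with a stated time of 72 h (on this read-out higher numbers stand for an effect only at larger amounts of compound and lower numbers for an effect already at smaller amounts), compound 2 `CC(C)(C)c1ccc(C(=O)/C=C/c2ccc([N+](=O)[O-])o2)cc1` gives 44500 nM. Among the compounds with values here, this sits at the high end of the numbers so far, within the scatter of compound 3 `O=C(/C=C/c1ccc([N+](=O)[O-])o1)c1ccc(-n2ccnc2)cc1` at 22600 nM and clearly apart from compound 1 `CCC(=O)Oc1cccc2ccc(/C=C/c3ccccc3[N+](=O)[O-])nc12` at 10100 nM.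

Compound 4 `O=C(/C=C/c1ccc([N+](=O)[O-])o1)c1ccc(N2CCCCC2)cc1` has piperidin-1-yl in place of tert-butyl on an aromatic carbon, para to a large group: piperidin-1-yl in place of tert-butyl on an aromatic carbon.

One measured swap at this place bears on the change. Putting 1H-imidazol-1-yl in place of tert-butyl gave a 2.0-fold lower number from compound 2 to compound 3 (0.29 log units; within the scatter). A single step is thin evidence, but no change beyond the scatter is expected in this assay, and the expected result is a 1.5-fold lower number from compound 2 to compound 4 (0.17 log units; within the scatter). Compound 4 is estimated at 30000 nM, with an expected range from 12000 nM to 65000 nM.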

Compound 4, half-maximal effective concentration: > 50000 nM
Compound 4: only a limit was reported; the forecaster's own chance of this, stated with the estimate: 10%; at least 1.6-fold (0.22 log units) between middle value and limit.
By their numbers in this assay, from the lowest: compound 1; then compounds 3 and 2 (each within the scatter of the next). At a limit, above all of these: compound 4.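

Compound 4 gives > 50000 nM as a limit and not a number. Within the data shown here, this position now shows a change beyond the scatter for the first time: an at least 2.2-fold higher number from compound 3 to compound 4 (0.34 log units; beyond the scatter) means that piperidin-1-yl and 1H-imidazol-1-yl do not read alike here. Against tert-butyl, an at least 1.1-fold higher number from compound 2 to compound 4 (0.05 log units; that floor lies within the scatter) says little, and the true size of that step stays unknown. Still open, as far as these compounds go, is how an open-chain amine such as dimethylamino, or a carboxylic acid, would read at this place, and whether any group here brings the number well down from those of compound 2 and compound 3.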